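Solubility notes: heteroaryl replacement at the saturated ring carbon

The compounds below may be only part of what the source reports. "The series", "measured", "known", "first", "only" and "open" are said of these compounds alone.

Within the data shown here, compound 1 `CC(=O)N1CCCC([C@@H]2[C@@H](C(=O)Nc3ccc(F)c(C#N)c3)c3ccccc3C(=O)N2CC(C)C)C1` gives 69000 nM in a physicochemical assay for solubility, in phosphate buffer, with a stated time of 18 h, at pH 7 (on this read-out lower numbers stand for lower solubility and higher numbers for higher solubility), the highest of the three numbers measured so far. Compound 2 `CC(C)CN1C(=O)c2ccccc2[C@H](C(=O)Nc2ccc(F)c(C#N)c2)[C@H]1c1ccco1` gives 13000 nM and compound 3 `CC(C)CN1C(=O)c2ccccc2[C@H](C(=O)Nc2ccc(F)c(C#N)c2)[C@H]1c1ccc(C#N)s1` gives 4900 nM. Compound 4 `CC(C)CN1C(=O)c2ccccc2[C@H](C(=O)Nc2ccc(F)c(C#N)c2)[C@H]1c1cncc(C#N)c1` differs from compound 1 in one place: 5-cyanopyridin-3-yl in place of 1-acetylpiperidin-3-yl on a saturated ring carbon. Among the measured compounds shown here, two measured steps bear directly on this change, a 5.3-fold lower number from compound 1 to compound 2 (0.72 log units; beyond the scatter) and a 14-fold lower number from compound 1 to compound 3 (1.15 log units; beyond the scatter), both lowering the number beyond the scatter, and the remaining step of a 2.7-fold lower number from compound 2 to compound 3 (0.42 log units; beyond the scatter) separates the two measured replacements from each other. A drop beyond the scatter is therefore expected for compound 4, of a size between those two steps, so that a 5.8-fold lower number from compound 1 to compound 4 (0.76 log units; beyond the scatter) is the estimated step. Compound 4 is expected to give 12000 nM in this assay, with a range from 4000 nM to 35000 nM.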

Compound 4, solubility: 60000 nM
The estimate for compound 4 lay 5.0-fold (0.70 log units) below the measured number, and the stated range ends below it.
By their numbers in this assay, from the lowest: compound 3; then compound 2; then compounds 4 and 1 (each within the scatter of the next).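

At this saturated ring carbon, an aromatic ring does not by itself lower the number in this assay: 5-cyanopyridin-3-yl gives a 1.2-fold lower number from compound 1 to compound 4 (0.06 log units; within the scatter). The choice of aromatic group matters, with a 12-fold higher number from compound 3 to compound 4 (1.09 log units; beyond the scatter) and a 4.6-fold higher number from compound 2 to compound 4 (0.66 log units; beyond the scatter). Compounds 3 and 4 both carry a nitrile on the aromatic ring, so its presence alone does not set the number.

Nothing shown gives a cause for these steps. Open, on these data alone, is whether an unsubstituted pyridin-3-yl would stay with compound 4 or fall towards compound 2, and how a basic amine such as piperidin-3-yl without its acetyl group would read.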